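Quinolinone series: methoxy to chloro and lipophilicity

This account rests on a few compounds, and the source may have more. Where it says the series, first, only, none or still open, it means among the compounds named here.

Measured so far:
compound 1, `CCCCC#Cc1c(C)[nH]c2ccc(OC)cc2c1=O`, 5.25
compound 2, `CCCCC#Cc1c(C)[nH]c2ccc(Cl)cc2c1=O`, 2.98
compound 3, `COc1cccc2[nH]c(C)c(Cc3ccccc3)c(=O)c12`, 2.11

In a physicochemical assay for lipophilicity, at pH 7.4 (on this read-out lower numbers stand for lower lipophilicity and higher numbers for higher lipophilicity), compound 1 gives 5.25 and compound 2 gives 2.98; the two share a core and differ by chloro in place of methoxy on an aromatic carbon, a change that made a number 2.27 log units lower from compound 1 to compound 2 (beyond the scatter). Compound 3 gives 2.11 in this assay, the lowest of the three numbers; the difference between its core and that of compound 1 is not broken down here.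

Compound 4, `Cc1[nH]c2cccc(Cl)c2c(=O)c1Cc1ccccc1`, has not yet been measured in this assay. It differs from compound 3 by chloro in place of methoxy on an aromatic carbon. This is the same kind of change as from compound 1 to compound 2, but the place differs: in compound 1 the exchanged group sits meta to a fused ring and para to a fused ring, in compound 3 it sits ortho to a fused ring and meta to a fused ring. Within the data shown here, a step in the same direction is expected for compound 4, estimated at a number 0.81 log units lower from compound 3 to compound 4 (beyond the scatter), because the one measured example made a number 2.27 log units lower from compound 1 to compound 2 (beyond the scatter); only one such step is known, so a wide range is kept. For compound 4 the expected value in this assay is 1.3, between 0 and 2.6.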

Compound 4, distribution coefficient: 2.65
The estimate for compound 4 lay 1.35 log units below the measured number; measured number above the stated range.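

In this assay chloro in place of methoxy on an aromatic carbon gave a number 0.54 log units higher from compound 3 to compound 4 (beyond the scatter) and thus ran opposite to a number 2.27 log units lower from compound 1 to compound 2 (beyond the scatter) on the other core; across these two cores, the exchange has no fixed direction. The two pairs differ both in the rest of the structure and in the place of the exchange, which in the new pair is ortho to a fused ring and meta to a fused ring, and two steps alone cannot separate these factors. No measurement shown here bears on the reason for the reversal.

From the compounds shown here alone, it remains open whether the reversal follows the place of the exchange or the rest of the core, and a methoxy-to-chloro pair at the same place on both cores would address this directly. Also open, going by these compounds, is how an amine or a carboxylic acid at this aromatic carbon would compare with methoxy and chloro on the shared core of the new pair.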